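The source may hold more compounds than are shown below. What is called first, only, known or untested is meant among the compounds shown, and "the series" means these compounds.

Measured so far in a toxicity assay on CCRF-CEM cells (Homo sapiens) for cytotoxicity; a higher number here means that more compound is tolerated, a lower number that less compound is tolerated:
Compound 1 `Nc1cccc2c1nc(-c1c(F)cccc1F)n2Cc1c(F)cccc1F` gives 26.3 uM.
Compound 2 `CN(C)c1cccc2c1nc(-c1c(F)cccc1F)n2Cc1c(F)cccc1F` gives > 100 uM, a limit of the assay and not a number.
Compound 3 `Fc1cccc(F)c1Cn1c(-c2c(F)cccc2F)nc2c(CCl)cccc21` gives 13.4 uM.

Compound 2 sits at the limit of > 100 uM in this assay, at which 1 of the 3 values shown sits; only a bound is known for it. Compound 4 `NCc1cccc2c1nc(-c1c(F)cccc1F)n2Cc1c(F)cccc1F` differs from compound 2 by aminomethyl in place of dimethylamino on an aromatic carbon. Within the data shown here, two measured steps bear on this change. Going from amino to dimethylamino, the tolerated amount rose, an at least 3.8-fold higher number from compound 1 to compound 2 (0.58 log units; beyond the scatter). Going from dimethylamino to chloromethyl, it fell, an at least 7.4-fold lower number from compound 2 to compound 3 (0.87 log units; beyond the scatter). Aminomethyl restores a hydrogen-bond donor that dimethylamino lacks, so a drop is expected, back toward the value of compound 1, 26.3 uM. Compound 4 is estimated at 25 uM, within 8 uM to 80 uM. The expected step is an at least 4.0-fold lower number from compound 2 to compound 4 (0.60 log units; beyond the scatter).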

Compound 4, half-maximal toxic concentration: 49.3 uM
Estimate against measurement, compound 4: 2.0-fold (0.29 log units) below, and the stated range covers the measured number.
By their numbers in this assay, from the lowest: compounds 3, 1 and 4 (each within the scatter of the next, the first and the last beyond it). At a limit, above all of these: compound 2.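

In this assay, inserting a chain carbon leaves the amine on this aromatic carbon without a readable effect: a 1.9-fold higher number from compound 1 to compound 4 (0.27 log units; within the scatter). With that chain carbon kept, the atom on it does matter, amino in place of chloro giving a 3.7-fold higher number from compound 3 to compound 4 (0.57 log units; beyond the scatter). The remaining step, an at least 2.0-fold lower number from compound 2 to compound 4 (0.30 log units; that floor lies within the scatter), is only a bound, resting on a limit and not a number: the limit of > 100 uM in this assay, at which 1 of the 4 values shown sits.

Open, going by these compounds, is whether dimethylaminomethyl would also reach a limit, which would separate the effect of the two methyl groups from that of the chain carbon. Also open, on these data alone, is how a longer aminoethyl chain or a carboxylic acid would read on this aromatic carbon.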